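A Fluoro-to-Methoxy Swap on a Weakly Active Series

The source may report more compounds than this note shows. Statements on the series, on what has been measured and on what is new or still open speak of the compounds shown alone.

Measured compounds in this study:
compound 1 `C=C1C[C@]23C[C@@]1(O)CC[C@H]2c1ccc(OS(=O)(=O)c2ccc(C)cc2)c(C)c1[C@@H]3Cn1cc(-c2ccc(OC)cc2)nn1` gives > 20000 nM
compound 2 `C=C1C[C@]23C[C@@]1(O)CC[C@H]2c1ccc(O)c(C)c1[C@@H]3Cn1cc(-c2ccc(F)cc2)nn1` gives > 20000 nM

In a functional assay on MCF7 cells (Homo sapiens) for cytotoxicity, read by MTT assay, with a stated time of 4 days (a lower number here means a stronger inhibitor, a higher number a weaker inhibitor), compound 1 reaches only a limit, > 20000 nM. Compound 2 likewise shows only a limit, > 20000 nM. Compound 2 therefore cannot be placed against compound 1 beyond (the limit of > 20000 nM in this assay, at which 2 of the 2 values shown sit). Compound 3 `C=C1C[C@]23C[C@@]1(O)CC[C@H]2c1ccc(O)c(C)c1[C@@H]3Cn1cc(-c2ccc(OC)cc2)nn1` carries methoxy in place of fluoro on an aromatic carbon; one bond further out this reads 4-fluorophenyl to 4-methoxyphenyl. Compound 1 already holds the methoxyphenyl group and sits at the same limit. No step beyond the scatter is expected from compound 2 to compound 3. Compound 3 is thus estimated at 30000 nM, between 10000 nM and 100000 nM. The expected step is a step that the limit leaves unreadable from compound 2 to compound 3.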

Compound 3, half-maximal inhibitory concentration: > 20000 nM
Compound 3: only a limit was reported (the forecaster's own chance of this, stated with the estimate: 80%); the middle value is on the limit's open side.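

No new step can be read among compound 1, compound 2 and compound 3, which all stay at a limit: the limit of > 20000 nM in this assay, at which 3 of the 3 values shown sit. As far as these compounds go, whether either structural difference among them changes activity in this assay remains open.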